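Solubility notes on an aza-core amide series

The compounds below may be only part of what the source reports. "The series", "measured", "known", "first", "only" and "open" are said of these compounds alone.

The series is followed in a physicochemical assay for solubility, in phosphate buffer, at pH 7.4; a lower number here means a less soluble compound, a higher number a more soluble compound. Compound 1 `Cn1cc(C(=O)Nc2ccc(-c3ccccc3)c(C(F)(F)F)c2)c(=O)c2cnccc21` gives < 1 ug/mL in this assay, and that figure is a limit of the assay rather than a measured number. Compound 2 `Cn1cc(C(=O)Nc2ccc(-c3ccccn3)c(C(F)(F)F)c2)c(=O)c2ccccc21` also returns only a limit, < 1 ug/mL, in this assay. Compound 3 `Cn1cc(C(=O)Nc2cnc(-c3ccccc3)c(C(F)(F)F)c2)c(=O)c2ccccc21` likewise returns only a limit, < 1 ug/mL, in this assay. Compound 1 therefore stands together with its two neighbours at the floor of the assay: the limit of < 1 ug/mL in this assay, at which 3 of the 3 values shown sit.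

Compound 4 `Cn1cc(C(=O)Nc2ccc(-c3ccccn3)c(C(F)(F)F)c2)c(=O)c2cnccc21` differs from compound 1 in a single place: pyridin-2-yl in place of phenyl on an aromatic carbon. Among the compounds with values here, no step between two measured compounds is available in this assay, so the size of such a change cannot be read from the values so far. With every measured value resting at the limit, the expected step of a number no lower from compound 1 to compound 4 (the limit leaves the size open) is none beyond the scatter, allowing at most a small rise. Compound 4 is expected to give 1 ug/mL in this assay, within 0.3 ug/mL to 3 ug/mL, and is most likely to be reported once more as a limit.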

Compound 4, solubility: < 1 ug/mL
Compound 4: a limit, no number; the forecaster's own chance of this, stated with the estimate: 70%; the middle value lies on the limit itself.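

Compound 1 and compound 4 both return only a limit in this assay, so no step can be read for pyridin-2-yl in place of phenyl: the limit of < 1 ug/mL in this assay, at which 4 of the 4 values shown sit. The compounds shown leave open how large the effect of any single change is in this assay.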